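Replacing the Sulfamoyl Group in a Glucokinase Regulatory Protein Inhibitor

A few compounds are considered here, and "the series" means these few. Any claim that something is new, unique, unknown or untested is made for them only; others in the source may bear on it.

Compound 1 `CC#C[C@H]1CN(S(=O)(=O)c2ccc(N)nc2)CCN1c1ccc(S(N)(=O)=O)cc1` gives 37 nM in an assay on cells (Hepatocyte) for inhibition of glucokinase regulatory protein (Mus musculus), with stated times of 20 min and 40 min (a higher number here means that more compound is needed for the effect, a lower number that less compound is needed), the only full number among the shown results. Compound 2 `CC#C[C@H]1CN(S(=O)(=O)c2ccc(N)nc2)CCN1c1ccc(S(=O)(=O)Nc2ccccc2)cc1` reaches only the assay limit > 12500 nM. Going by the values given here, the step of an at least 330-fold higher number from compound 1 to compound 2 (2.52 log units; beyond the scatter) is thus the single measured change, and it rests on (the limit of > 12500 nM in this assay, at which 1 of the 2 values shown sits). Compound 3 `CC#C[C@H]1CN(S(=O)(=O)c2ccc(N)nc2)CCN1c1ccc(C(O)(CC#N)C(F)(F)F)cc1` differs from compound 1 by a group of 9 heavy atoms (4 carbon, 1 nitrogen, 1 oxygen, 3 fluorine; no ring) in place of a group of 4 heavy atoms (1 nitrogen, 2 oxygen, 1 sulfur; no ring), on an aromatic carbon. That measured step alters the same group in another way, so it bears on this change only loosely, and a modest loss is expected, a 3.2-fold higher number from compound 1 to compound 3 (0.51 log units; beyond the scatter). Compound 3 is therefore estimated at 120 nM, between 30 nM and 600 nM.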

Compound 3, half-maximal effective concentration: 219 nM
For compound 3 the middle estimate is 1.8-fold (0.26 log units) below the measured one; low and high end bracket the measured number.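

Sulfamoyl is not indispensable on this aromatic carbon: a group without sulfur costs only a 5.9-fold higher number from compound 1 to compound 3 (0.77 log units; beyond the scatter) in this assay. Replacing the phenyl-bearing sulfonamide with this group, which has no ring, gives an at least 57-fold lower number from compound 2 to compound 3 (1.75 log units; beyond the scatter), so a larger group than sulfamoyl is compatible with activity here, while the substituent with a ring is not. Compound 2 stands at a limit, not a number: the limit of > 12500 nM in this assay, at which 1 of the 3 values shown sits.

Which part of the new group matters, the hydroxyl, the nitrile or the trifluoromethyl, remains open. So does whether a carboxylic acid or an amine on this carbon would come closer to compound 1.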